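Replacing 3-carboxypropyl with cyclopentyl on a carbonyl carbon

This account rests on a few compounds, and the source may have more. Where it says the series, first, only, none or still open, it means among the compounds named here.

Measured in an ADME assay on HepG2 2.2.15 cells (Homo sapiens) for cytotoxicity (a higher number here means that more compound is tolerated, a lower number that less compound is tolerated), so far:
Compound 1 `Cn1c(=O)c(CCO)c(-c2ccccc2Cl)c2cc(Cl)ccc21` gives 34000 nM
Compound 2 `O=CCc1c(-c2ccccc2Cl)c2cc(Cl)ccc2[nH]c1=O` gives 120000 nM
Compound 3 `O=C(O)CCCC(=O)OCCc1c(-c2ccccc2Cl)c2cc(Cl)ccc2[nH]c1=O` gives 110000 nM

Compound 3 sits with compound 2 at the top of these three numbers, while compound 1 lies clearly lower. Still unmeasured, compound 4 `O=C(OCCc1c(-c2ccccc2Cl)c2cc(Cl)ccc2[nH]c1=O)C1CCCC1` carries cyclopentyl in place of 3-carboxypropyl on a carbonyl carbon and is otherwise the same as compound 3. The closest measured step is a 1.1-fold lower number from compound 2 to compound 3 (0.04 log units; within the scatter) and it stayed within the scatter, although it did not involve cyclopentyl. The only hint of a lower number is compound 1 at 34000 nM but that compound differs in more than one place. In this assay only a small downward move is therefore expected, perhaps none beyond the scatter. The expected step is a 1.6-fold lower number from compound 3 to compound 4 (0.20 log units; within the scatter) in this estimate. Compound 4 is estimated at 70000 nM with an expected range from 25000 nM to 160000 nM in this assay.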

Compound 4, half-maximal cytotoxic concentration: 46000 nM
The estimate for compound 4 lay 1.5-fold (0.18 log units) above the measured number; measured number inside the range.
By their numbers in this assay, from the lowest: compounds 1 and 4 (each within the scatter of the next); then compounds 3 and 2 (each within the scatter of the next).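

In this assay, among the compounds shown here, the group on this carbonyl carbon proves able to move the number: cyclopentyl in place of 3-carboxypropyl gives a 2.4-fold lower number from compound 3 to compound 4 (0.38 log units; beyond the scatter), a shift beyond the scatter that the earlier compounds did not show. The comparison with formyl agrees, with ((cyclopentylcarbonyl)oxy)methyl giving a 2.6-fold lower number from compound 2 to compound 4 (0.42 log units; beyond the scatter), while the 3-carboxypropyl ester had stayed within the scatter of compound 2. No available evidence accounts for this shift. The compounds shown leave open whether an amine or a phenyl ring on this carbonyl carbon would track with cyclopentyl or with 3-carboxypropyl.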